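The source may report more compounds than this note shows. Statements on the series, on what has been measured and on what is new or still open speak of the compounds shown alone.

Working notes on a series built on one shared core. Compound 1 `Nc1ccccc1NC(=O)c1ccc(CSC(=S)N2CCN(c3ccccc3)CC2)cc1` and compound 2 `CC1CCCCN1C(=S)SCc1ccc(C(=O)Nc2ccccc2N)cc1` have been tested in a functional assay on MGC-803 cells (Homo sapiens) for antiproliferative activity, read by CCK-8 assay, with a stated time of 72 h, tested at 8 uM; a lower number here means a weaker effect, a higher number a stronger effect of the compound at the concentration tested. Compound 1 gives 87.4% in this assay, and compound 2 gives 86.9%. The two numbers lie within the scatter of one another, so compound 1 stands level with compound 2 and no order between them can be read. Going by the values given here, no step between measured compounds that differ in a single place is available.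

Compound 3 `Nc1ccccc1NC(=O)c1ccc(CSC(=S)N2CCN(Cc3ccncc3)CC2)cc1` remains to be measured in this assay. Relative to compound 1 it differs by (pyridin-4-yl)methyl in place of phenyl on an amine nitrogen in a ring. Compound 1 at 87.4% and compound 2 at 86.9% differ from each other elsewhere in structure yet sit together. The step is therefore expected to be a number 4.4 percentage points lower from compound 1 to compound 3 (within the scatter), none beyond the scatter. Compound 3 is estimated at 83%, with a range from 65% to 93%.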

Compound 3, a percentage reported as inhibition, at one concentration (the size of the read-out at that concentration, not a potency): 79.3%
Compound 3: middle estimate off by 3.7 percentage points, on the high side; low and high end bracket the measured number.
By their numbers in this assay, from the lowest: compounds 3, 2 and 1 (each within the scatter of the next).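

In this assay, (pyridin-4-yl)methyl in place of phenyl on an amine nitrogen in a ring gives a number 8.1 percentage points lower from compound 1 to compound 3 (within the scatter). Going by these compounds alone, this is the first step that can be read at a single place, and it shows that this nitrogen carries either an aromatic ring of carbon only or a methyl-linked ring with a hetero atom and a hydrogen-bond acceptor, with no difference beyond the scatter. No measurement bearing on the reason for this result is at hand.

From the compounds shown here alone, the ring nitrogen and the methyl link enter together, so their separate contributions stay open, and benzyl on the same nitrogen would separate them. Also open, going by these compounds, is how a carboxylic acid or a longer chain at this position would read, and whether potency would follow the single-concentration picture.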